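Replacing a fluorophenyl with a methoxyphenethyl chain

The compounds below may be only part of what the source reports. "The series", "measured", "known", "first", "only" and "open" are said of these compounds alone.

Compound 1 `CCCCCCCCS(=O)(=O)Nc1cc(-c2ccccc2-c2ccccc2)ccc1C(=O)O`: 17100 nM
Compound 2 `CCCCCCCCS(=O)(=O)Nc1cc(-c2ccc(-c3ccccc3)cc2)ccc1C(=O)O`: 13500 nM
Compound 3 `CCCCCCCCS(=O)(=O)Nc1cc(-c2ccccc2F)ccc1C(=O)O`: 47200 nM

In an assay on mitochondria (strain BALB/c) for inhibition of glycerol-3-phosphate acyltransferase 1, mitochondrial (Mus musculus), read by scintillation counting, with a stated time of 10 min (a lower number here means a stronger inhibitor, a higher number a weaker inhibitor), compound 3 gives the highest number of the three and is the weakest inhibitor measured so far; compound 2 gives the lowest, and compound 1 lies between them. Compound 4 `CCCCCCCCS(=O)(=O)Nc1cc(CCc2ccc(OC)cc2)ccc1C(=O)O` differs from compound 3 by 2-(4-methoxyphenyl)ethyl in place of 2-fluorophenyl on an aromatic carbon. Among the measured compounds shown here, the one measured step touching this place is a 2.8-fold higher number from compound 1 to compound 3 (0.44 log units; beyond the scatter), where the smaller fluoro gave the higher number; compound 2 carries a still larger group there and shows a lower number than compound 1. Putting a larger group back in compound 4 is therefore expected to lower the number by a modest step, a 2.4-fold lower number from compound 3 to compound 4 (0.37 log units; beyond the scatter). Compound 4 is estimated at 20000 nM, with a likely range from 8000 nM to 50000 nM.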

Compound 4, half-maximal inhibitory concentration: 43000 nM
Compound 4: middle estimate off by 2.2-fold (0.33 log units), on the low side, within the range that was stated.
By their numbers in this assay, from the lowest: compounds 2 and 1 (each within the scatter of the next); then compounds 4 and 3 (each within the scatter of the next).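

In this assay, putting 2-(4-methoxyphenyl)ethyl in place of 2-fluorophenyl gives a 1.1-fold lower number from compound 3 to compound 4 (0.04 log units; within the scatter), so this change does not separate the two compounds. The earlier compounds shown here tied a larger group at this position to a lower number, but compound 4, with 10 heavy atoms entering for 7, goes against that link. Nothing measured here accounts for this result.

On these data alone, it remains open whether the ethyl link or the methoxy group governs the number in compound 4, and whether an amine in place of that methoxy group would change it.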